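A few compounds are considered here, and "the series" means these few. Any claim that something is new, unique, unknown or untested is made for them only; others in the source may bear on it.

In an ADME assay on microsomes from liver (Homo sapiens) for metabolic stability (a lower number here means that the compound disappears faster, a higher number that the compound lasts longer), compound 1 `CC(C)C(c1ccc(-c2ccc3cccc(F)c3c2)[nH]c1=O)N1CCCCC1=O` gives 0.183 h. Compound 2 `CC(C)C(c1noc(=O)[nH]1)c1ccc(-c2ccc3cccc(F)c3c2)[nH]c1=O` gives > 3 h, which is a limit of the measurement and not a number. That places compound 2 at the limit of > 3 h in this assay, at which 1 of the 2 values shown sits. Compound 3 `CC(C)C(/C=C1/CCNC1=O)c1ccc(-c2ccc3cccc(F)c3c2)[nH]c1=O` has not been measured yet, and the change from compound 2 is a group of 7 heavy atoms (5 carbon, 1 nitrogen, 1 oxygen; one five-membered non-aromatic ring with 1 hetero atom) in place of a group of 6 heavy atoms (2 carbon, 2 nitrogen, 2 oxygen; one five-membered aromatic ring with 3 hetero atoms), on a saturated chain carbon bound to an aromatic carbon and a saturated chain carbon. The entering group has 7 heavy atoms (5 carbon, 1 nitrogen, 1 oxygen), the same count as the group on compound 1, although its ring is five-membered rather than six-membered. For the measured compounds named here, one measured step bears on this, and it ran the other way: an at least 16-fold higher number from compound 1 to compound 2 (1.21 log units; beyond the scatter), a large step beyond the scatter. Compound 3 therefore looks set to give back much of that gain, though perhaps not all of it, given the different ring. The expected change is an at least 6.0-fold lower number from compound 2 to compound 3 (0.77 log units; beyond the scatter), a large fall in this assay. For compound 3 the estimated half-life is 0.5 h, with an expected range from 0.15 h to 2 h.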

Compound 3, half-life: 0.987 h
Compound 3: middle estimate off by 2.0-fold (0.30 log units), on the low side, within the range that was stated.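

In this assay the saturated chain carbon now carries three different groups, and swapping one ring of 7 heavy atoms for another with the same atom count is not neutral: the change gives a 5.4-fold higher number from compound 1 to compound 3 (0.73 log units; beyond the scatter) and shows that part of the gain in lasting longer does not need the five-membered aromatic ring with 3 hetero atoms. That aromatic ring still stays ahead at this position, with an at least 3.0-fold lower number from compound 2 to compound 3 (0.48 log units; beyond the scatter) showing that the five-membered non-aromatic ring recovers only part of its effect. The value of compound 2 is a limit of the assay and not a number: the limit of > 3 h in this assay, at which 1 of the 3 values shown sits.

The compounds shown do not separate ring size from the way each ring is attached to the chain carbon. As far as these compounds go, how a carboxylic acid or a simple amine would fare at this position also remains open.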